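The source may report more compounds than this note shows. Statements on the series, on what has been measured and on what is new or still open speak of the compounds shown alone.

Compounds measured in an ADME assay on A549 cells (Homo sapiens) for cytotoxicity, read by resazurin assay, with a stated time of 48 h; on this read-out lower numbers stand for higher toxicity in this test and higher numbers for lower toxicity in this test:

Compound 1, `CCCCCCC(C)Nc1ccc(NC(=O)c2cc(Cl)ccc2O)c(Cl)c1`, gives 23500 nM.
Compound 2, `O=C(Nc1ccc(NCC2CCCC2)cc1Cl)c1cc(Cl)ccc1O`, gives 21500 nM.
Compound 3, `O=C(Nc1ccc(NCc2ccncc2)cc1Cl)c1cc(Cl)ccc1O`, gives 65300 nM.

Compound 3 stands highest of the three numbers, that is, it is the least toxic of them in this assay. The step of a 2.8-fold higher number from compound 1 to compound 3 (0.44 log units; beyond the scatter) and the step of a 3.0-fold higher number from compound 2 to compound 3 (0.48 log units; beyond the scatter) are both modest but beyond the scatter, whereas the step of a 1.1-fold lower number from compound 1 to compound 2 (0.04 log units; within the scatter) lies within it, so compound 1 and compound 2 cannot be ordered against each other.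

Compound 4, `O=C(Nc1ccc(N(CCCO)CCCO)cc1Cl)c1cc(Cl)ccc1O`, differs from compound 3 in one place: bis(3-hydroxypropyl)amino in place of ((pyridin-4-yl)methyl)amino on an aromatic carbon. The two steps that bear on this position, the step from compound 1 to compound 3 and the step from compound 2 to compound 3, show that exchanging the group on this nitrogen shifted the number only modestly, and in both cases toward lower toxicity when the (pyridin-4-yl)methyl group entered. Going by the values given here, no measured pair tests the bis(3-hydroxypropyl)amino group itself, so its direction is not established. The step of a 1.1-fold higher number from compound 3 to compound 4 (0.03 log units; within the scatter) is therefore expected to stay small, around the scatter. Compound 4 is estimated at 70000 nM, within a range of 30000 nM to 160000 nM.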

Compound 4, half-maximal cytotoxic concentration: 114000 nM
The estimate for compound 4 lay 1.6-fold (0.21 log units) below the measured number; the range from low to high includes it.
By their numbers in this assay, from the lowest: compounds 2 and 1 (each within the scatter of the next); then compounds 3 and 4 (each within the scatter of the next).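

In this assay the ringless bis(3-hydroxypropyl)amino group takes the place of ((pyridin-4-yl)methyl)amino without a change that can be told from the scatter (a 1.7-fold higher number from compound 3 to compound 4 (0.24 log units; within the scatter)), so among these compounds the aromatic ring of the leaving group is not required for a number at this level. Measured against the two amino groups whose substituents hold carbon only, the same group gives steps that are modest but beyond the scatter (a 5.3-fold higher number from compound 2 to compound 4 (0.72 log units; beyond the scatter); a 4.9-fold higher number from compound 1 to compound 4 (0.69 log units; beyond the scatter)), which places compound 3 and compound 4, the two whose substituents on this nitrogen carry a hetero atom, together on the less toxic side of compound 1 and compound 2, with no compound shown going against this. No supporting measurement is available to explain this result.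

The compounds shown do not separate the contribution of the hydroxyl groups from that of having two chains on this nitrogen, a question that a single 3-hydroxypropyl chain or two unsubstituted propyl chains would address. As far as these compounds go, it also remains open how this position would respond to a carboxylic acid at the chain end or to a morpholine ring on the aromatic carbon.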